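Bromophenyl to Fluorophenyl on the Amide-Type Nitrogen

A few compounds are considered here, and "the series" means these few. Any claim that something is new, unique, unknown or untested is made for them only; others in the source may bear on it.

Measured so far:
compound 1 `CN(C)C(=O)c1cc2cnc(Nc3ccc(NC(=O)C4(C(=O)Nc5cccc(O)c5)CC4)cc3)nc2n1C1CCCC1` — 86%
compound 2 `CN(C)C(=O)c1cc2cnc(Nc3ccc(NC(=O)C4(C(=O)Nc5ccc(Br)cc5)CC4)cc3)nc2n1C1CCCC1` — 87.8%
compound 3 `CN(C)C(=O)c1cc2cnc(Nc3ccc(NC(=O)C4(C(=O)Nc5cccc(Br)c5)CC4)cc3)nc2n1C1CCCC1` — 89.6%

In a functional assay on OVCAR-5 cells (Homo sapiens) for inhibition, read by CCK-8 assay, with a stated time of 72 h, tested at 10 uM (on this read-out higher numbers stand for more inhibition of growth at the one concentration tested and lower numbers for less inhibition of growth), compound 2 gives 87.8%. Its nearest neighbour is compound 1 and its furthest is compound 3, and both gaps are within the scatter, so the three measured compounds stand on one level. Compound 4 `CN(C)C(=O)c1cc2cnc(Nc3ccc(NC(=O)C4(C(=O)Nc5cccc(F)c5)CC4)cc3)nc2n1C1CCCC1` has not yet been measured; compared with compound 2 the change is 3-fluorophenyl in place of 4-bromophenyl on an amide-type nitrogen. The measured steps that bear on this are the earlier changes of the group on the amide-type nitrogen, which gave a number 1.8 percentage points higher from compound 1 to compound 2 (within the scatter) and a number 1.8 percentage points higher from compound 2 to compound 3 (within the scatter), while the direct swap of bromo for hydroxy gave a number 3.6 percentage points higher from compound 1 to compound 3 (within the scatter); none went beyond the scatter. The step of a number 0.8 percentage points lower from compound 2 to compound 4 (within the scatter) is therefore expected to be of the same kind, none beyond the scatter. Compound 4 is expected to give 87%, within a range from 78% to 93%.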

Compound 4, percent growth inhibition at one concentration: 85.6%
Beside the measured number, compound 4's estimate is 1.4 percentage points above it, within the range that was stated.
By their numbers in this assay, from the lowest: compounds 4, 1, 2 and 3 (each within the scatter of the next).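

In this assay the 3-fluorophenyl group on the amide-type nitrogen stands level with the three earlier groups: the result is a number 2.2 percentage points lower from compound 2 to compound 4 (within the scatter) and a number 4 percentage points lower from compound 3 to compound 4 (within the scatter) and a number 0.4 percentage points lower from compound 1 to compound 4 (within the scatter). Fluoro, bromo and hydroxy on the aromatic carbon therefore cannot be told apart here, and a fourth group leaves the number at this position on the same level. Nothing available here explains this flat picture. 

An amine, a carboxylic acid or a longer chain in place of the phenyl ring might still move the number. From the compounds shown here alone, because all four compounds share one level at a single concentration, any differences that a full dose-response curve might reveal remain open.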